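The source may hold more compounds than are shown below. What is called first, only, known or untested is meant among the compounds shown, and "the series" means these compounds.

Compound 1 `Cc1nn([C@H](C)c2ccc(Cl)cc2Cl)c2nc(N3CC[C@H](N4CCC[C@H]4C(N)=O)[C@H](C)C3)cnc12` is the weaker of the two measured compounds. In a functional assay on cells for antagonist activity at C-C chemokine receptor type 4 (Homo sapiens), read by fluorescence and calcium flux, with stated times of 2.5 s and 45 s (a higher number here means a weaker inhibitor, a lower number a stronger inhibitor), compound 1 gives 170 nM, the highest of the two numbers recorded. For the measured compounds named here, compound 2 `Cc1nn([C@H](C)c2ccc(Cl)cc2Cl)c2nc(C3=CC[C@H](N4CCC[C@H]4CO)[C@H](C)C3)cnc12`, which shares the same core but is otherwise built differently, gives 36 nM in this assay, a lower number that lies beyond the usual scatter of the assay; no single-point step connects these two compounds, so their values can only be set side by side.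

Compound 3 `Cc1nn([C@H](C)c2ccc(Cl)cc2Cl)c2nc(N3CC[C@H](N4CCC[C@H]4C(=O)O)[C@H](C)C3)cnc12` has not yet been measured. It differs from compound 1 in one place (hydroxy in place of amino on a carbonyl carbon). Going by the values given here, no measured pair shows a change of this kind, so the direction of the step has to be judged from the change alone. The author expects a step of a 2.6-fold higher number from compound 1 to compound 3 (0.42 log units; beyond the scatter) from compound 1 to compound 3 in this assay, toward a weaker inhibitor, with wide uncertainty. Compound 3 is estimated to give 450 nM, within a range of 120 nM to 2000 nM.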

Compound 3, half-maximal inhibitory concentration: 670 nM
Beside the measured number, compound 3's estimate is 1.5-fold (0.17 log units) below it, within the range that was stated.
By their numbers in this assay, from the lowest: compound 2; then compound 1; then compound 3.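

In this assay, exchanging carbamoyl for carboxy on the pyrrolidine gives a 3.9-fold higher number from compound 1 to compound 3 (0.60 log units; beyond the scatter) and moves toward a weaker inhibitor. For the compounds shown here, this is the first step in the set that changes one place only, and it shows that this carbonyl substituent is not indifferent: replacing amino with hydroxy alters a single heavy atom, with the same computed count of hydrogen-bond donors and acceptors, yet the shift lies beyond the scatter. Nothing available accounts for the size or direction of this step.

The compounds shown leave open how a methyl ester, a methylamide or a nitrile would read on this same saturated ring carbon. They also leave open whether the same exchange would give a step of similar direction on another version of the shared core.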